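The source may report more compounds than this note shows. Statements on the series, on what has been measured and on what is new or still open speak of the compounds shown alone.

Series notes, opening.

The shared core carries a benzyl bearing trifluoromethyl on a triazole whose amide links to an acid-bearing group. Compound 1 `C[C@H](NC(=O)c1c(-c2ccc(F)cc2)nnn1Cc1ccc(C(F)(F)F)cc1)c1ccc(C(=O)O)cc1` has a fluorophenyl on the triazole and a methyl-branched link; in a functional assay on CHO cells for antagonist activity at prostaglandin E2 receptor EP4 subtype (Homo sapiens), read by calcium flux, with a stated time of 15 min (on this read-out lower numbers stand for stronger inhibition and higher numbers for weaker inhibition), compound 1 gives 57.9 nM. Compound 2 `C/C=C/c1nnn(Cc2ccc(C(F)(F)F)cc2)c1C(=O)NCc1ccc(C(=O)O)cc1` has a propenyl on the triazole and an unbranched link; in this assay compound 2 gives 10.5 nM. For the measured compounds named here, of the two numbers measured so far, compound 2 stands lowest, and the gap to compound 1 lies beyond the scatter.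

Compound 3 `C/C=C/c1nnn(Cc2ccc(C(F)(F)F)cc2)c1C(=O)NCC1CCC(C(=O)O)CC1` is not yet measured. It differs from compound 2 in one place: 4-carboxycyclohexyl in place of 4-carboxyphenyl on a saturated chain carbon bound to an amide-type nitrogen. Going by the values given here, no measured pair in this set covers such a change, so nothing here shows how this assay responds to it. The acid and the propenyl and the benzyl group are kept, and only the ring that carries the acid is altered. A step is expected in this assay somewhat beyond the scatter, toward a higher number, written as a 2.4-fold higher number from compound 2 to compound 3 (0.38 log units; beyond the scatter). Compound 3 is thus estimated at 25 nM in this assay, within a range from 6 nM to 100 nM.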

Compound 3, half-maximal inhibitory concentration: 13.9 nM
Estimate against measurement, compound 3: 1.8-fold (0.25 log units) above, and the stated range covers the measured number.
By their numbers in this assay, from the lowest: compounds 2 and 3 (each within the scatter of the next); then compound 1.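

In this assay, for the compounds shown here, replacing 4-carboxyphenyl with 4-carboxycyclohexyl on a saturated chain carbon bound to an amide-type nitrogen gives a 1.3-fold higher number from compound 2 to compound 3 (0.12 log units; within the scatter), the first one-place step, so the two acid-bearing rings cannot be told apart on this read-out. With the propenyl and the benzyl group kept, this pair shows that an aromatic ring is not needed at this place for a number of this order, as compound 3 gives 13.9 nM with a six-membered non-aromatic ring of carbon only. No measurement at hand offers an explanation for how closely the two rings read.

From the compounds shown here alone, it stays open whether the two rings would also read alike with the fluorophenyl and the methyl-branched link of compound 1, which differs from compound 2 and compound 3 in more than one place. Also open, going by these compounds, is how this assay would respond to a tetrazole in place of the carboxylic acid on the cyclohexyl ring, or to a longer chain in place of the single saturated chain carbon.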